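Amide aryl swap from compound 2 to compound 3

A few compounds are considered here, and "the series" means these few. Any claim that something is new, unique, unknown or untested is made for them only; others in the source may bear on it.

Compound 2 `CCOC(=O)C1=Cc2ccccc2OC1(OCc1cn(CC(=O)Nc2ccc(I)cc2Cl)nn1)C(F)(F)F` holds the highest of the two numbers in a functional assay on MCF7 cells (Homo sapiens) for inhibition, read by MTT assay, with a stated time of 24 h (on this read-out higher numbers stand for weaker inhibition and lower numbers for stronger inhibition), giving 28100 nM; compound 1 `CCOC(=O)C1=Cc2ccccc2OC1(OCc1cn(CC(=O)NC2CCCCC2)nn1)C(F)(F)F` gives 12100 nM. For the measured compounds named here, the single measured step, a 2.3-fold higher number from compound 1 to compound 2 (0.37 log units; beyond the scatter), is modest. Compound 3 `CCOC(=O)C1=Cc2ccccc2OC1(OCc1cn(CC(=O)Nc2cccc(F)c2)nn1)C(F)(F)F` carries 3-fluorophenyl in place of 2-chloro-4-iodophenyl on an amide-type nitrogen. Going by the values given here, no measured pair exchanges one aryl amide for another, so that step bears on this change only loosely, and no step beyond the scatter is expected in this assay. Compound 3 is therefore estimated at 18000 nM, with a range of 7000 nM to 45000 nM. The expected change is a 1.6-fold lower number from compound 2 to compound 3 (0.19 log units; within the scatter).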

Compound 3, half-maximal inhibitory concentration: > 150000 nM
Compound 3 gave a limit, no number (the forecaster's own chance of this, stated with the estimate: 10%); middle value at least 8.3-fold (0.92 log units) from the limit.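

In this assay compound 3 reads only as a limit, not a number: the limit of > 150000 nM in this assay, at which 1 of the 3 values shown sits.

One aryl amide in place of another on the amide-type nitrogen is therefore not a neutral exchange, giving an at least 5.3-fold higher number from compound 2 to compound 3 (0.72 log units; beyond the scatter). Against the cyclohexyl amide, 3-fluorophenyl gives an at least 12-fold higher number from compound 1 to compound 3 (1.09 log units; beyond the scatter); compound 2 and compound 3 share the aromatic ring, so the aryl ring alone does not set the read-out.

The contributions of chlorine, iodine and fluorine remain unseparated, as all three change in one step. Going by these compounds, how an unsubstituted phenyl group on this nitrogen would read remains open.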